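This account rests on a few compounds, and the source may have more. Where it says the series, first, only, none or still open, it means among the compounds named here.

In an assay on isolated protein for inhibition of Dihydrofolate reductase (Homo sapiens), read by spectrophotometry, using NADPH, with stated times of 5 s and 6 min, tested at 5 uM (on this read-out higher numbers stand for a stronger effect at the one concentration tested and lower numbers for a weaker effect), compound 1 `NC1=NC2(CCSCC2)N(OCCCOc2ccc(Cl)c(Cl)c2)C(N)=N1` gives 88.4%. Compound 2 `NC1=NC2(CCSCC2)N(OCCCOc2cccc(Cl)c2)C(N)=N1` differs from it by hydrogen in place of chloro on an aromatic carbon, and in this assay compound 2 gives 88.3%, so the step of a number 0.1 percentage points lower from compound 1 to compound 2 (within the scatter) hardly moves the read-out. Compound 3 `NC1=NC2(CCOCC2)N(OCCCOc2cccc(Cl)c2Cl)C(N)=N1` carries a different core; how that core differs from the core of compound 1 is not broken down here. In this assay compound 3 gives 81.7%, which is within the scatter of the other two results.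

Compound 4 `NC1=NC2(CCOCC2)N(OCCCOc2ccccc2Cl)C(N)=N1` has not yet been measured. It differs from compound 3 by hydrogen in place of chloro on an aromatic carbon. This is the same kind of change as from compound 1 to compound 2, but not the same: in compound 1 the leaving chloro sits para to a large group, in compound 3 it sits meta to a large group. Because the step of a number 0.1 percentage points lower from compound 1 to compound 2 (within the scatter) was within the scatter, the step from compound 3 to compound 4 is expected to be small as well, about a number 1.7 percentage points lower from compound 3 to compound 4 (within the scatter). Compound 4 is therefore estimated to give 80% in this assay, most likely between 68% and 90%.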

Compound 4, a percentage reported as inhibition, at one concentration (the size of the read-out at that concentration, not a potency): 83.3%
Compound 4: middle estimate off by 3.3 percentage points, on the low side; the measured number falls inside the stated range.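

In this assay, the change from 2,3-dichlorophenyl to 2-chlorophenyl, with hydrogen taking the place of a chloro on the aromatic ring, gives a number 1.6 percentage points higher from compound 3 to compound 4 (within the scatter). Set beside the earlier step on the other core, the same kind of change behaves alike on both cores, with no detectable shift in either case: the same change on two cores in this assay, a number 0.1 percentage points lower (within the scatter) from compound 1 to compound 2 and a number 1.6 percentage points higher (within the scatter) from compound 3 to compound 4, 1.7 percentage points apart, within the scatter of two such steps This shows only that, in these two pairs, losing one chloro leaves the read-out within its usual scatter; it does not show that the change would carry over to other cores, or that the chloro never matters, and a percentage at one concentration gives only the size of the effect at that concentration, so compounds that read alike here could still show a stronger or weaker effect at other concentrations.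

The compounds shown leave open how the read-out would respond if the remaining chloro gave way to a plain hydrogen, a methoxy group or an amine. Also open, on these data alone, is what a longer chain in place of the present linker would do.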